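Two Double Bonds Enter a Saturated Heptyl Tail

The source may report more compounds than this note shows. Statements on the series, on what has been measured and on what is new or still open speak of the compounds shown alone.

Compound 2 `CCCCCCCCC/C=C/C=C/C(=O)NCC(C)(C)O` gives 58.3% in a functional assay on cells (Platelet, Oryctolagus cuniculus) for inhibition, read by turbidimetry, with a stated time of 3 min, tested at 50 ug/mL (a higher number here means a weaker effect of the compound at the concentration tested, a lower number a stronger effect), the higher of the two measured numbers. Compound 1 `C/C=C/C=C/C=C\CC/C=C/C=C/C(=O)NC(C)(C)O` gives 19.9% in this assay, a number lower by a margin that lies beyond the usual scatter. Compound 3 `CC/C=C/C/C=C\CC/C=C/C=C/C(=O)NCC(C)(C)O` differs from compound 2 in one place: hepta-1,4-dien-1-yl in place of heptyl on a saturated chain carbon, two bonds along the chain from a double-bonded chain carbon. Among the compounds with values here, no measured pair shows exactly this change. For compound 3 the expected step is a number 23.3 percentage points lower from compound 2 to compound 3 (beyond the scatter), a move toward a lower number beyond the scatter, because compound 1 gives 19.9%. Compound 3 is estimated at 35%, with a range from 15% to 60%.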

Compound 3, a percentage reported as activity, at one concentration (the size of the read-out at that concentration, not a potency): 0%
For compound 3 the middle estimate is 35 percentage points above the measured one; measured number below the stated range.
By their numbers in this assay, from the lowest: compound 3; then compound 1; then compound 2.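

In this assay, putting hepta-1,4-dien-1-yl in place of heptyl gives a number 58.3 percentage points lower from compound 2 to compound 3 (beyond the scatter) as the result of this one change. The tail keeps the same number of carbon atoms, so two double bonds in the chain, without any added atoms, are enough to shift the read-out strongly toward a stronger effect. No measurement here explains this step.

Whether both double bonds are needed remains open, since the compounds shown do not separate them. As far as these compounds go, how a longer chain, or a carboxylic acid at the end of the tail, would compare also remains open.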